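Ring Contraction and a Shifted Amine on a Shared Core

This account rests on a few compounds, and the source may have more. Where it says the series, first, only, none or still open, it means among the compounds named here.

Compound 1, `CCC(CC)N1CCN(c2nc3c(c(Nc4ccc(C(F)(F)F)cc4)n2)CCN(c2ncccc2C(F)(F)F)CC3)CC1`: 185 nM
Compound 2, `CC(C)(C)OC(=O)N1CCCC(Nc2nc3c(c(Nc4ccc(C(F)(F)F)cc4)n2)CCN(c2ncccc2C(F)(F)F)CC3)C1`: 239 nM
Compound 3, `CN(c1nc2c(c(Nc3ccc(C(F)(F)F)cc3)n1)CCN(c1ncccc1C(F)(F)F)CC2)C1CCCNC1`: 1540 nM

Of the compounds shown here, three built on one shared core have been tested in a functional assay on HEK293 cells for antagonist activity at transient receptor potential cation channel subfamily V member 1 (Rattus norvegicus), read by FLIPR and calcium flux; on this read-out higher numbers stand for weaker inhibition and lower numbers for stronger inhibition. Compound 3 gives the highest of the three numbers, so on this read-out it is the weakest inhibitor of the set. Compound 2 and compound 1 both give clearly lower numbers, with compound 1 furthest away from compound 3.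

Compound 4, `CNC1CCN(c2nc3c(c(Nc4ccc(C(F)(F)F)cc4)n2)CCN(c2ncccc2C(F)(F)F)CC3)C1`, differs from compound 3 in a single place: 3-(methylamino)pyrrolidin-1-yl in place of methyl(piperidin-3-yl)amino on an aromatic carbon. Among the compounds with values here, only one measured step bears on this change: an 8.3-fold higher number from compound 1 to compound 3 (0.92 log units; beyond the scatter). In that step a group joined to the core through a ring nitrogen gave way to an amine joined through a nitrogen outside its ring, and the number rose well beyond the scatter. Compound 4 returns to a group joined through a ring nitrogen, though the ring is now five-membered and carries the methylamino group on its side. A partial return toward the lower numbers of compound 1 is therefore expected, as a modest step of a 2.6-fold lower number from compound 3 to compound 4 (0.41 log units; beyond the scatter). For compound 4 in this assay the estimate is 600 nM, within a range from 200 nM to 1800 nM.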

Compound 4, half-maximal inhibitory concentration: > 5000 nM
Compound 4: no number, only a limit; the forecaster's own chance of this, stated with the estimate: 3%; at least 8.3-fold (0.92 log units) between middle value and limit.
By their numbers in this assay, from the lowest: compounds 1 and 2 (each within the scatter of the next); then compound 3. At a limit, above all of these: compound 4.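

In this assay, compound 4 gives a limit of the assay and not a number: the limit of > 5000 nM in this assay, at which 1 of the 4 values shown sits.

Even so, the direction is clear: placing 3-(methylamino)pyrrolidin-1-yl on this aromatic carbon, between the two ring nitrogen atoms, gives an at least 3.2-fold higher number from compound 3 to compound 4 (0.51 log units; beyond the scatter), and the comparison with the 4-(pentan-3-yl)piperazin-1-yl group gives an at least 27-fold higher number from compound 1 to compound 4 (1.43 log units; beyond the scatter). Compound 1 and compound 4 are both joined to the shared core through a ring nitrogen, yet they lie at opposite ends of the series, so that kind of link alone does not bring back the low number of compound 1, and this position clearly responds to the choice of amine group.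

The compounds shown leave open whether the rise goes with the five-membered ring, with the methylamino group on it, or with the two together. A 3-(dimethylamino)pyrrolidin-1-yl group or a 4-(methylamino)piperidin-1-yl group at the same carbon would help to separate these possibilities, and a number for either could be compared directly with compound 4.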